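Propoxy to cyclopropyl on the carbonyl: what compound 4 may give

The compounds below may be only part of what the source reports. "The series", "measured", "known", "first", "only" and "open" are said of these compounds alone.

Compound 1 `CCCOC(=O)C1=C(C)NC(=O)NC1c1ccco1` gives 3% in an assay on membranes from HeLa cells for displacement of a labelled ligand from adenosine receptor A3 (Homo sapiens), read by scintillation counting, with a stated time of 180 min, tested at 1 uM; on this read-out higher numbers stand for more inhibition at the one concentration tested (going by the name of the read-out) and lower numbers for less inhibition.
Compound 2 `CCCOC(=O)C1=C(C)NC(=O)NC1c1ccoc1` gives 11% in this assay.
Compound 3 `CCCOC(=O)C1=C(C)N(C)C(=O)NC1c1ccoc1` gives 16% in this assay.

Compound 2 holds the second highest of the three numbers, yet a number 8 percentage points higher from compound 1 to compound 2 (within the scatter) and a number 5 percentage points higher from compound 2 to compound 3 (within the scatter) both lie within the scatter, so no order among the three is claimed. Compound 4 `CC1=C(C(=O)C2CC2)C(c2ccoc2)NC(=O)N1` differs from compound 2 as follows: cyclopropyl in place of propoxy on a carbonyl carbon. Neither measured step touches the carbonyl substituent: one moves the furan attachment point, the other methylates a ring nitrogen, and both stay within the scatter. Among the compounds with values here, no measured step therefore bears on this change, and no step beyond the scatter is expected. The step of no change at the digits printed from compound 2 to compound 4 (within the scatter) is expected to stay within the scatter. In this assay compound 4 is thus expected to give 11%, between 0% and 30%.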

Compound 4, a percentage reported as inhibition, at one concentration (the size of the read-out at that concentration, not a potency): 16%
The estimate for compound 4 lay 5 percentage points below the measured number; the measured number falls inside the stated range.
By their numbers in this assay, from the lowest: compounds 1, 2, 3 and 4 (each within the scatter of the next, the first and the last beyond it).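

In this assay, within the data shown here, the change from propoxy to cyclopropyl on a carbonyl carbon gives a number 5 percentage points higher from compound 2 to compound 4 (within the scatter), the first reading at this position. Cyclopropyl, with its three-membered ring and without the oxygen of propoxy, therefore leaves the number within the scatter of compound 2. Nothing available explains this reading.

From the compounds shown here alone, it remains open whether an amine or a butoxy chain on this carbonyl carbon would give a step beyond the scatter. Going by these compounds, it also remains open whether cyclopropyl would read the same alongside furan-2-yl or the ring nitrogen methyl.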